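The source may report more compounds than this note shows. Statements on the series, on what has been measured and on what is new or still open speak of the compounds shown alone.

Measured so far in a functional assay on the whole organism with Rattus norvegicus as the target, with a stated time of 4 h, at a dose of 40 mg/kg by the intraperitoneal route; a higher number here means more inhibition at the dose given (going by the name of the read-out), a lower number less inhibition:
compound 1, `Cc1cn2cccc(OCc3ccccc3)c2n1`, gives 62%
compound 2, `Cc1nc2c(OCc3ccccc3)cccn2c1C#N`, gives 25%
compound 3, `Cc1nc2c(OCc3ccccc3)cccn2c1Cl`, gives 93%

Compound 3 stands highest of the three. Its nearest neighbour is compound 1, and the gap is a number 31 percentage points higher from compound 1 to compound 3 (beyond the scatter). The furthest is compound 2, and that gap is a number 68 percentage points higher from compound 2 to compound 3 (beyond the scatter).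

The next compound, compound 4, `Cc1nc2c(OCc3ccccc3)cccn2c1C`, is not yet measured. It differs from compound 3 in a single place: methyl in place of chloro on an aromatic carbon

Going by the values given here, three measured steps touch the same aromatic carbon of the shared core. Putting chloro in place of hydrogen gave a number 31 percentage points higher from compound 1 to compound 3 (beyond the scatter), putting cyano in place of hydrogen gave a number 37 percentage points lower from compound 1 to compound 2 (beyond the scatter), and putting chloro in place of cyano gave a number 68 percentage points higher from compound 2 to compound 3 (beyond the scatter). Among the compounds with values here, none of these steps involves a methyl group, so the change from compound 3 to compound 4 has no direct precedent here. What the numbers do show is that this position is sensitive: the group sitting there moved the read-out by large amounts in both directions. Because compound 3 already stands at 93%, and because chloro was the best of the groups tried, a methyl group is expected to give a step of a number 23 percentage points lower from compound 3 to compound 4 (beyond the scatter), downward, towards the level of compound 1. Compound 4 is therefore estimated to give 70% in this assay, within a range from 40% to 95%.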

Compound 4, a percentage reported as inhibition, in the whole organism at one dose (the size of the read-out at that dose, not a potency): 99%
The estimate for compound 4 lay 29 percentage points below the measured number; the whole stated range lies below it.
By their numbers in this assay, from the lowest: compound 2; then compound 1; then compounds 3 and 4 (each within the scatter of the next).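

Read in this assay the step of methyl in place of chloro is a number 6 percentage points higher from compound 3 to compound 4 (within the scatter) and so chloro and methyl cannot be told apart at this aromatic carbon. Methyl in place of hydrogen gives a number 37 percentage points higher from compound 1 to compound 4 (beyond the scatter) and methyl in place of cyano gives a number 74 percentage points higher from compound 2 to compound 4 (beyond the scatter) so the large rise over hydrogen first seen with chloro does not belong to chloro alone. Among the four groups shown at this carbon, chloro and methyl, each a single heavy atom, stand together at the top, with hydrogen lower and cyano lowest of all.

As far as these compounds go, whether an ethyl group, a methoxy group, an amine or a carboxylic acid at this carbon would stay at the level of chloro and methyl remains open, and a read-out at a single dose says nothing about the relative potency of compound 3 and compound 4. No measurement at hand explains why chloro and methyl match or why cyano sits so far below them.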